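A few compounds are considered here, and "the series" means these few. Any claim that something is new, unique, unknown or untested is made for them only; others in the source may bear on it.

Measured so far:
- compound 1, `N#Cc1ccc(Nc2nc(N)nc(Oc3ccc4ccccc4c3Br)n2)cc1`, 133000 nM in an ADME assay on MT4 cells (Homo sapiens) for cytotoxicity, read by MTT assay, with a stated time of 4 days; a higher number here means that more compound is tolerated, a lower number that less compound is tolerated
- compound 2, `CNc1nc(Nc2ccc(C#N)cc2)nc(Oc2ccc3ccccc3c2Cl)n1`, 171000 nM in this assay

Both compounds were run in this assay, which asks how much of each compound the cells tolerate. Compound 2 has the highest of the two numbers, but its nearest neighbour is compound 1, whose number is lower only within the scatter, so the two cannot be told apart.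

Compound 3 has the structure `N#Cc1ccc(Nc2nc(N)nc(Oc3ccc4ccccc4c3Cl)n2)cc1` and has not yet been measured. It differs from compound 2 in one place: hydrogen in place of methyl on a nitrogen on an aromatic ring. Cut one bond further out, the change reads methylamino to amino.

Within the data shown here, no directly comparable step between measured compounds exists here. Compound 1 already carries the amino group, and its number in this assay sits within the scatter of compound 2. On that basis the step from compound 2 to compound 3 is expected to be small, a 1.1-fold lower number from compound 2 to compound 3 (0.06 log units; within the scatter), with no clear direction beyond the scatter.

Compound 3 is therefore estimated to give 150000 nM in this assay, with a likely range from 75000 nM to 300000 nM.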

Compound 3, half-maximal cytotoxic concentration: 32200 nM
The estimate for compound 3 lay 4.7-fold (0.67 log units) above the measured number, and the stated range ends above it.
By their numbers in this assay, from the lowest: compound 3; then compounds 1 and 2 (each within the scatter of the next).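

With the chloro kept on the aromatic carbon, hydrogen in place of methyl on the nitrogen gives a 5.3-fold lower number from compound 2 to compound 3 (0.73 log units; beyond the scatter) in this assay, and with the amino group kept, chloro in place of bromo gives a 4.1-fold lower number from compound 1 to compound 3 (0.62 log units; beyond the scatter), so in this series each of these two places can change the number beyond the scatter on its own. Neither change could be read alone from compound 1 and compound 2, which differ in both places, and only compound 3 shows that the cells tolerate less of it than of either neighbour, with both steps about the same modest size. No measurement shown gives a reason for either step.

The compounds shown leave open whether the methylamino to amino step keeps its size when bromo replaces chloro, and so whether the two changes act independently of each other. They also leave open where the number would go with a longer chain on that nitrogen, such as ethylamino, or with fluoro in place of chloro on the aromatic carbon.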